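The source may hold more compounds than are shown below. What is called first, only, known or untested is meant among the compounds shown, and "the series" means these compounds.

Working notes on the spiro series.

Three compounds have numbers in an assay on HEK293 cells for displacement of a labelled ligand from NPC1-like intracellular cholesterol transporter 1 (Homo sapiens); on this read-out higher numbers stand for weaker inhibition and lower numbers for stronger inhibition. Compound 1 `CCOC(=O)C1CCN(C(=O)CN2CN(c3ccccc3)C3(CCN(C(=O)c4ccc(C5CCCCC5)cc4)CC3)C2=O)CC1` gives 900 nM. Compound 3 `CC(C)(C)OC(=O)NCC1CCCN(C(=O)CN2CN(c3ccccc3)C3(CCN(C(=O)c4ccc(C5CCCCC5)cc4)CC3)C2=O)C1` gives 3800 nM. Compound 2 `CC(C)(C)OC(=O)NCCNC(=O)CN1CN(c2ccccc2)C2(CCN(C(=O)c3ccc(C(C)(C)C)cc3)CC2)C1=O` gives 10900 nM, which is the highest of the three numbers; the nearest is compound 3, with a step beyond the scatter, and the furthest is compound 1, with a larger gap, also beyond the scatter. Compound 2 thus stands as the weakest inhibitor of the three on this read-out. No pair among these three differs in only one place, so no single-point step is available from them.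

Compound 4 `CC(C)(C)c1ccc(C(=O)N2CCC3(CC2)C(=O)N(CC(=O)NCCO)CN3c2ccccc2)cc1` has not been measured in this assay. It differs from compound 2 in one place: hydroxy in place of (tert-butoxycarbonyl)amino on a saturated chain carbon, two bonds along the chain from an amide-type nitrogen. The shared core, the phenyl on the core and the tert-butyl-bearing benzoyl group are kept.

For the measured compounds named here, nothing measured speaks directly to this change, and the series gives no step to lean on. The expected step from compound 2 to compound 4 is a 1.4-fold lower number from compound 2 to compound 4 (0.13 log units; within the scatter), a small move that may well sit within the scatter. Compound 4 is expected to give 8000 nM in this assay, with a range from 2500 nM to 30000 nM.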

Compound 4, half-maximal inhibitory concentration: 1000 nM
Beside the measured number, compound 4's estimate is 8.0-fold (0.90 log units) above it; measured number outside the range, below it.
By their numbers in this assay, from the lowest: compounds 1 and 4 (each within the scatter of the next); then compound 3; then compound 2.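

In this assay this exchange gives the series its first single-change reading: hydroxy in place of (tert-butoxycarbonyl)amino, on a saturated chain carbon two bonds along the chain from an amide-type nitrogen, brings an 11-fold lower number from compound 2 to compound 4 (1.04 log units; beyond the scatter) while the shared core, the phenyl and the tert-butyl-bearing benzoyl group stay as they are. The position therefore responds strongly to what it carries, and at this place the group of 8 heavy atoms is not needed for stronger inhibition, since a single oxygen as hydroxy serves better on this read-out. Nothing at hand accounts for the size of the step, so it stands as an observation without a cause.

Still open, as far as these compounds go, is whether the stronger inhibition belongs to the hydroxy itself or only to the departure of the (tert-butoxycarbonyl)amino group, which a free amine, a methoxy or a carboxylic acid at the same place, or a longer chain ending in hydroxy, would help to separate. Also open, from the compounds shown here alone, is whether the same exchange would bring a similar step on the cyclohexyl-bearing benzoyl group of compound 3, whose chain is built differently.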